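Triazole Substituent Removal in a Monoamine Oxidase A Series

The source may hold more compounds than are shown below. What is called first, only, known or untested is meant among the compounds shown, and "the series" means these compounds.

Measured compounds:
compound 1 `O=C1O[C@@H](Cn2cc(CO)nn2)CN1c1ccc(C2=CCS(=O)(=O)CC2)c(F)c1`, 47000 nM
compound 2 `O=C1O[C@@H](Cn2cc(Cl)nn2)CN1c1ccc(C2=CCS(=O)(=O)CC2)c(F)c1`, 3000 nM

For the measured compounds named here, in an assay for binding affinity to Amine oxidase [flavin-containing] A (Homo sapiens) (on this read-out higher numbers stand for weaker inhibition and lower numbers for stronger inhibition), compound 1 gives 47000 nM, the highest of the two numbers so far; its nearest neighbour is compound 2, which in this assay gives 3000 nM. Going by the values given here, the one measured step, a 16-fold lower number from compound 1 to compound 2 (1.19 log units; beyond the scatter), is the only comparison available and is large.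

Compound 3 `O=C1O[C@@H](Cn2ccnn2)CN1c1ccc(C2=CCS(=O)(=O)CC2)c(F)c1` is not yet measured. It differs from compound 1 by hydrogen in place of hydroxymethyl on an aromatic carbon. Among the compounds with values here, only the step to compound 2 bears on this change, and it shows that a smaller group than hydroxymethyl at this aromatic carbon gave a much lower number. Hydrogen is a different replacement from chloro, so the step of a 3.9-fold lower number from compound 1 to compound 3 (0.59 log units; beyond the scatter) is expected to run in the same direction but with less confidence in its size. Compound 3 is therefore expected to give about 12000 nM in this assay, within a range of 3000 nM to 47000 nM.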

Compound 3, inhibition constant: 3400 nM
Beside the measured number, compound 3's estimate is 3.5-fold (0.55 log units) above it; the measured number falls inside the stated range.
By their numbers in this assay, from the lowest: compounds 2 and 3 (each within the scatter of the next); then compound 1.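

In this assay, a 14-fold lower number from compound 1 to compound 3 (1.14 log units; beyond the scatter) shows that the much lower number needs no chloro at this aromatic carbon of the five-membered aromatic ring with 3 nitrogen: hydrogen serves as well. With a 1.1-fold higher number from compound 2 to compound 3 (0.05 log units; within the scatter), hydrogen and chloro cannot be told apart here, so among these three compounds only the hydroxymethyl of compound 1 stands apart, and no group at this carbon is needed to reach the level of compound 2. Nothing available accounts for the high number that goes with hydroxymethyl.

Still open, as far as these compounds go, is whether that number follows the hydroxyl oxygen or the added carbon, which a methyl group at this carbon would separate. Also open, from the compounds shown here alone, is how an amine, a carboxylic acid or a longer chain here would read, and whether any group gives a lower number than compound 2 and compound 3.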